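Cyclohexyl in place of isobutyl on compound 2

The source may report more compounds than this note shows. Statements on the series, on what has been measured and on what is new or still open speak of the compounds shown alone.

In an ADME assay on A549 cells (Homo sapiens) for cytotoxicity, read by resazurin assay, with a stated time of 48 h (on this read-out lower numbers stand for higher toxicity in this test and higher numbers for lower toxicity in this test), compound 2 (`CC(C)CNc1ccc(NC(=O)c2cc(Cl)ccc2O)c(Cl)c1`) gives 60000 nM, the highest of three numbers, against compound 1 (`CC(C)Nc1ccc(NC(=O)c2cc(Cl)ccc2O)c(Cl)c1`) at 11000 nM and compound 3 (`CCCCCCCCC(C)Nc1ccc(NC(=O)c2cc(Cl)ccc2O)c(Cl)c1`) at 21900 nM. Compound 4 (`O=C(Nc1ccc(NC2CCCCC2)cc1Cl)c1cc(Cl)ccc1O`) follows from cyclohexyl in place of isobutyl on a nitrogen on an aromatic ring, with cyclohexyl in place of isobutyl on a nitrogen on an aromatic ring. Among the measured compounds shown here, two measured steps bear on this. Isobutyl in place of isopropyl gives a 5.5-fold higher number from compound 1 to compound 2 (0.74 log units; beyond the scatter), the only step involving isobutyl. Heptyl in place of hydrogen gives a 2.0-fold higher number from compound 1 to compound 3 (0.30 log units; within the scatter). Since compound 4 loses the isobutyl group, a return towards the lower numbers is expected, with a drop of moderate size. The expected step is a 2.7-fold lower number from compound 2 to compound 4 (0.44 log units; beyond the scatter). Compound 4 is estimated at 22000 nM, with an expected range of 9000 nM to 55000 nM.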

Compound 4, half-maximal cytotoxic concentration: 68300 nM
For compound 4 the middle estimate is 3.1-fold (0.49 log units) below the measured one; the whole stated range lies below it.
By their numbers in this assay, from the lowest: compounds 1 and 3 (each within the scatter of the next); then compounds 2 and 4 (each within the scatter of the next).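

Cyclohexyl in place of isobutyl on this nitrogen gives a 1.1-fold higher number from compound 2 to compound 4 (0.06 log units; within the scatter) in this assay, so here a six-membered carbon ring reads the same as the open branched chain. Set against isopropyl, the same ring gives a 6.2-fold higher number from compound 1 to compound 4 (0.79 log units; beyond the scatter), which places it with compound 2 at the high end of the series, while compound 3 stays within the scatter of compound 1. No data on hand offer an explanation for this result.

Going by these compounds, it remains open whether a phenyl ring, a cyclopropyl ring, or a chain carrying an amine or a carboxylic acid on this nitrogen would hold the number at this level.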